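A few compounds are considered here, and "the series" means these few. Any claim that something is new, unique, unknown or untested is made for them only; others in the source may bear on it.

Compound 2 `Cc1nc2c(Br)c(Br)c(Br)c(Br)c2n1CCC#N` carries the shared core with a short chain that ends in a nitrile. Among the compounds with values here, in a functional assay on CCRF-CEM cells (Homo sapiens) for cytotoxicity, read by MTT assay, with a stated time of 24 h, tested at 20 uM (on this read-out higher numbers stand for a weaker effect at the one concentration tested and lower numbers for a stronger effect), compound 2 gives 51%, the lowest of the two numbers measured so far; its nearest neighbour is compound 1 `Cc1nc2c(Br)c(Br)c(Br)c(Br)c2n1CCCCC#N`, which in this assay gives 61%, and the gap between them stays within the usual scatter. Compound 3 `Cc1nc2c(Br)c(Br)c(Br)c(Br)c2n1CCCC#N` has not yet been measured. It differs from compound 2 by cyanomethyl in place of cyano on a saturated chain carbon, two bonds along the chain from an aromatic nitrogen, so the chain between the aromatic nitrogen and the nitrile grows. Within the data shown here, the one measured step that bears on this is a change of chain length: a number 10 percentage points lower from compound 1 to compound 2 (within the scatter). Because that step a number 10 percentage points lower from compound 1 to compound 2 (within the scatter) stayed within the scatter, compound 3 is expected to show a number 5 percentage points higher from compound 2 to compound 3 (within the scatter), nothing beyond the scatter. Compound 3 is therefore estimated at 56% in this assay, with a range from 40% to 72%.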

Compound 3, a percentage reported as activity, at one concentration (the size of the read-out at that concentration, not a potency): 44%
Estimate against measurement, compound 3: 12 percentage points above; low and high end bracket the measured number.
By their numbers in this assay, from the lowest: compounds 3, 2 and 1 (each within the scatter of the next, the first and the last beyond it).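

The change from 2-cyanoethyl to 3-cyanopropyl gives a number 7 percentage points lower from compound 2 to compound 3 (within the scatter), so in this assay this single change cannot be told apart from the noise of repeated measurements. Chain length does register over a wider span: the step of a number 17 percentage points lower from compound 1 to compound 3 (beyond the scatter) is the first here to pass the scatter, and it points to a stronger effect at the one concentration tested for compound 3. Compound 2, with the shortest chain of the three, lies within the scatter of both other compounds, so the numbers do not establish a steady trend with length.

Nothing measured here explains why the chain changes the read-out. On these data alone, it also remains open whether the nitrile itself matters, which a similar chain ending in an amine or a carboxylic acid could test, and how a chain longer than that of compound 1 would behave.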